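Replacing the (1-phenylethyl)amino group of compound 2

This account rests on a few compounds, and the source may have more. Where it says the series, first, only, none or still open, it means among the compounds named here.

In a toxicity assay on C8166 cells (Homo sapiens) for cytotoxicity, read by MTT assay, with a stated time of 72 h (on this read-out higher numbers stand for lower toxicity in this test and lower numbers for higher toxicity in this test), compound 2 (`C[C@@H](Nc1c(C(=O)NCc2ccc(F)cc2)nc(Br)c2cccnc12)c1ccccc1`) reads "not determined" (no result reported) and so offers no number to start from. The change to compound 4 (`Cc1ccc(S(=O)(=O)Oc2c(C(=O)NCc3ccc(F)cc3)nc(Br)c3cccnc23)cc1`) is ((4-methylphenyl)sulfonyl)oxy in place of (1-phenylethyl)amino on an aromatic carbon and it sits para to a bromo group. For the measured compounds named here, only two related compounds carry numbers: compound 1 (`O=C(NCc1ccc(F)cc1)c1nc(NCCO)c2cccnc2c1O`) gives 91000 nM and compound 3 (`C[C@H](CO)Nc1nc(C(=O)NCc2ccc(F)cc2)c(O)c2ncccc12`) gives 69000 nM in this test. Their step, a 1.3-fold lower number from compound 1 to compound 3 (0.12 log units; within the scatter) lies within the scatter and does not involve this exchange. No step size or direction can therefore be expected from compound 2. In this assay compound 4 is expected near 50000 nM with an estimated range from 10000 nM to 150000 nM as a rough guide.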

Compound 4, half-maximal cytotoxic concentration: 31000 nM
Compound 4: the middle estimate sits 1.6-fold (0.21 log units) above what was measured; the measured number falls inside the stated range.
By their numbers in this assay, from the lowest: compound 4; then compounds 3 and 1 (each within the scatter of the next).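

For the compounds shown here, compound 2 offers no number in this assay, so no step to compound 4 can be read, though compound 4 gives 31000 nM. No evidence bears on this result. The compounds shown leave open how exchanging (1-phenylethyl)amino for ((4-methylphenyl)sulfonyl)oxy shifts this read-out.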